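The compounds below may be only part of what the source reports. "The series", "measured", "known", "first", "only" and "open" are said of these compounds alone.

Of the compounds shown here, three that share one core have been tested for their ability to slow the growth of a human colon cancer cell line. Compound 1 `Cc1cc(S(=O)(=O)/N=C(\N)N/N=C/C#Cc2ccccc2)c(SCc2ccccc2C(F)(F)F)cc1Cl` and compound 2 `C/C(C#Cc1ccccc1)=N\N/C(N)=N/S(=O)(=O)c1cc(C)c(Cl)cc1SCc1ccccc1C(F)(F)F` differ by a group of 11 heavy atoms (10 carbon, 1 nitrogen; one six-membered aromatic ring of carbon only) in place of a group of 10 heavy atoms (9 carbon, 1 nitrogen; one six-membered aromatic ring of carbon only), on an amine nitrogen. Compound 3 `Cc1cc(S(=O)(=O)/N=C(\N)N/N=C/C#Cc2ccccc2)c(SCc2ccc(C(F)(F)F)cc2)cc1Cl` differs from compound 1 by 4-(trifluoromethyl)phenyl in place of 2-(trifluoromethyl)phenyl on a saturated chain carbon bound to a sulfur. In a functional assay on HCT-116 cells (Homo sapiens) for antiproliferative activity, read by MTT assay, with a stated time of 72 h (on this read-out higher numbers stand for weaker inhibition and lower numbers for stronger inhibition), compound 1 gives 18000 nM, compound 2 gives 23000 nM and compound 3 gives 70000 nM. The first change gave a 1.3-fold higher number from compound 1 to compound 2 (0.11 log units; within the scatter), so on this read-out compound 1 and compound 2 cannot be told apart. The second change gave a 3.9-fold higher number from compound 1 to compound 3 (0.59 log units; beyond the scatter), and compound 3 stands weakest of the three measured.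

Compound 4 `C/C(C#Cc1ccccc1)=N\N/C(N)=N/S(=O)(=O)c1cc(C)c(Cl)cc1SCc1ccc(C(F)(F)F)cc1` has not yet been measured. It differs from compound 3 by a group of 11 heavy atoms (10 carbon, 1 nitrogen; one six-membered aromatic ring of carbon only) in place of a group of 10 heavy atoms (9 carbon, 1 nitrogen; one six-membered aromatic ring of carbon only), on an amine nitrogen, the same change, at the same place, that turns compound 1 into compound 2; the two pairs are built on cores that differ by 4-(trifluoromethyl)phenyl in place of 2-(trifluoromethyl)phenyl on a saturated chain carbon bound to a sulfur. Since that change moved the value of compound 1 only little, as a 1.3-fold higher number from compound 1 to compound 2 (0.11 log units; within the scatter) shows, compound 4 is expected to sit close to compound 3, with an estimated 1.3-fold higher number from compound 3 to compound 4 (0.11 log units; within the scatter). On that reasoning compound 4 is estimated at 90000 nM in this assay, with a likely range from 40000 nM to 200000 nM. The measured result for compound 4 will show whether the two cores respond alike to this change.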

Compound 4, half-maximal inhibitory concentration: 160000 nM
Beside the measured number, compound 4's estimate is 1.8-fold (0.25 log units) below it, within the range that was stated.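

In this assay, carrying the swap of the group on the amine nitrogen over to the second core gives a 2.3-fold higher number from compound 3 to compound 4 (0.36 log units; beyond the scatter), and this step cannot be told apart from the earlier one: the same change on two cores in this assay, a 1.3-fold higher number (0.11 log units; within the scatter) from compound 1 to compound 2 and a 2.3-fold higher number (0.36 log units; beyond the scatter) from compound 3 to compound 4, 1.8-fold (0.25 log units) apart, within the scatter of two such steps. Moving from 2-(trifluoromethyl)phenyl to 4-(trifluoromethyl)phenyl also carries over, giving a 7.0-fold higher number from compound 2 to compound 4 (0.84 log units; beyond the scatter), which again matches the earlier step: the same change on two cores in this assay, a 3.9-fold higher number (0.59 log units; beyond the scatter) from compound 1 to compound 3 and a 7.0-fold higher number (0.84 log units; beyond the scatter) from compound 2 to compound 4, 1.8-fold (0.25 log units) apart, within the scatter of two such steps. Going by these compounds alone, in these four compounds, then, each change has much the same effect on both cores, but this rests on only two pairs for each change and does not show that either change would behave the same way on other cores.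

The compounds shown leave open what would happen if a chlorine atom or a methoxy group took the place of the trifluoromethyl group, or if an amine or a carboxylic acid took the place of the phenyl ring in the group on the amine nitrogen. They also leave open whether any such replacement would give a clearly lower number than compound 1 gives, 18000 nM.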